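A few compounds are considered here, and "the series" means these few. Any claim that something is new, unique, unknown or untested is made for them only; others in the source may bear on it.

Going by the values given here, in a physicochemical assay for solubility, read by nephelometry, measured as kinetic solubility, at pH 2 (on this read-out lower numbers stand for lower solubility and higher numbers for higher solubility), compound 3 `O=C(Nc1ccc(F)c(C(F)(F)F)c1)Nc1cnccn1` gives 1.6 ug/mL as the only true number among the values shown so far. Compound 1 `CC(=O)c1ccc(NC(=O)Nc2ccc(F)c(C(F)(F)F)c2)cc1` gives < 1.6 ug/mL as a limit of the assay, not a number. Compound 2 `O=C(Nc1ccc(C(=O)O)cc1)Nc1ccc(F)c(C(F)(F)F)c1` gives < 1.6 ug/mL as a limit too.

Compound 4 `O=C(Nc1ccncc1)Nc1ccc(F)c(C(F)(F)F)c1` keeps the rest of compound 3 and carries pyridin-4-yl in place of pyrazin-2-yl on an amide-type nitrogen (in full: pyridin-4-yl in place of pyrazin-2-yl on an amide-type nitrogen). Among the compounds with values here, no measured step covers this swap. Within the data shown here, the only step between two measured relatives, with hydroxy in place of methyl on a carbonyl carbon, is a step that the two limits leave unreadable from compound 1 to compound 2 and so offers no size to carry over. The other guide is the floor of the data so far (the limit of < 1.6 ug/mL in this assay, at which 2 of the 3 values shown sit).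

Compound 3 at 1.6 ug/mL leaves little room for a readable fall, so any readable change in this assay is expected to go upward, with no measured size behind it. The estimated change is a 5.0-fold higher number from compound 3 to compound 4 (0.70 log units; beyond the scatter) and it is expected to be moderate, though the uncertainty is wide. Compound 4 is estimated at 8 ug/mL with an expected range from 1.6 ug/mL to 50 ug/mL in this assay once it is measured.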

Compound 4, solubility: 6.3 ug/mL
The estimate for compound 4 lay 1.3-fold (0.10 log units) above the measured number; measured number inside the range.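

In this assay, going by these compounds alone, the swap gives the first step with a readable size: a 3.9-fold higher number from compound 3 to compound 4 (0.60 log units; beyond the scatter). It shows that the group on this amide-type nitrogen can shift the read-out even when the change is small: both groups have 6 heavy atoms, a six-membered aromatic ring and no net charge, and pyridin-4-yl has 1 hetero atom where pyrazin-2-yl has 2. Within the data shown here, the only earlier step cannot be read, and compound 1 and compound 2 remain at a limit of the assay, not a number: the limit of < 1.6 ug/mL in this assay, at which 2 of the 4 values shown sit.

This one step cannot separate the effect of losing a ring nitrogen from the effect of where the remaining one sits, and a comparison with pyridin-3-yl or pyrimidin-5-yl on the same nitrogen would help to tell those two apart. It also leaves open how a non-aromatic group, such as morpholine or a short chain ending in an amine, would read in this assay at this place.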